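Aryl substituent swap in the chalcone series

A few compounds are considered here, and "the series" means these few. Any claim that something is new, unique, unknown or untested is made for them only; others in the source may bear on it.

Compound 2 `COc1ccc(-c2cn(-c3cccc(C(=O)/C=C/c4ccc(O)c(OC)c4)c3)c(=O)[nH]2)cc1` is the higher of the two numbers seen so far in a functional assay on OVCAR-4 cells (Homo sapiens) for inhibition; on this read-out lower numbers stand for stronger inhibition of growth and higher numbers for weaker inhibition of growth. In this assay compound 2 gives 6080 nM, and compound 1 `COc1cc(/C=C/C(=O)c2cccc(-n3cc(-c4ccccc4)[nH]c3=O)c2)ccc1O` gives 5190 nM; the change a 1.2-fold higher number from compound 1 to compound 2 (0.07 log units; within the scatter) is within the scatter, so the two stand level. Compound 3 `COc1cc(/C=C/C(=O)c2cccc(-n3cc(-c4ccc(Cl)cc4)[nH]c3=O)c2)ccc1O` differs from compound 2 by chloro in place of methoxy on an aromatic carbon, placed on an aromatic carbon of a six-membered aromatic ring of carbon only, para to a large group. For the measured compounds named here, only one measured step bears on this site: the step from compound 1 to compound 2, where a methoxy replaced hydrogen at the same position, and its size a 1.2-fold higher number from compound 1 to compound 2 (0.07 log units; within the scatter) was within the scatter. Substitution here has so far left the number unchanged, so no step beyond the scatter is expected for compound 3 and a 1.1-fold lower number from compound 2 to compound 3 (0.04 log units; within the scatter) is estimated. Compound 3 is therefore expected to give 5500 nM, in the range 2500 nM to 12000 nM.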

Compound 3, concentration for 50% growth inhibition: 4640 nM
Estimate against measurement, compound 3: 1.2-fold (0.07 log units) above, and the stated range covers the measured number.
By their numbers in this assay, from the lowest: compounds 3, 1 and 2 (each within the scatter of the next).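

Chloro in place of methoxy gives a 1.3-fold lower number from compound 2 to compound 3 (0.12 log units; within the scatter) in this assay, and chloro in place of hydrogen gives a 1.1-fold lower number from compound 1 to compound 3 (0.05 log units; within the scatter) as the second comparison at this site. For the compounds shown here, the position on the six-membered aromatic ring of carbon only now carries hydrogen, methoxy and chloro, and no step among compounds 1, 2 and 3 lies beyond the scatter, so the swap from 4-methoxyphenyl to 4-chlorophenyl leaves the three compounds level. No measurement on hand offers an explanation for this result.

As far as these compounds go, whether an amine, a carboxylic acid or a longer chain such as butoxy at this position would move the number beyond the scatter remains open. The compounds shown also leave open whether these level numbers would hold on cells other than those of this read-out.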